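Aryl variation on the shared core: toward compound 4

The source may report more compounds than this note shows. Statements on the series, on what has been measured and on what is new or still open speak of the compounds shown alone.

Compound 1 `Oc1ccc(-c2cc(-c3ccc(Cl)cc3)nc(-c3cccnc3)c2)cc1`: 20700 nM
Compound 2 `Oc1ccc(-c2cc(-c3ccc(Cl)cc3)nc(-c3ccsc3)c2)cc1`: 6240 nM
Compound 3 `Oc1ccc(-c2cc(-c3ccsc3)nc(-c3ccccc3Cl)c2)cc1`: 5830 nM

In a functional assay on HCT-15 cells (Homo sapiens) for cytotoxicity, read by CCK-8 assay and cell counting, with a stated time of 2 days (on this read-out lower numbers stand for stronger inhibition and higher numbers for weaker inhibition), compound 2 stands second highest of the three numbers, nearest to compound 3 (a 1.1-fold lower number from compound 2 to compound 3 (0.03 log units; within the scatter)) and furthest from compound 1 (a 3.3-fold lower number from compound 1 to compound 2 (0.52 log units; beyond the scatter)). Compound 4 `Oc1ccc(-c2cc(-c3ccc(Cl)cc3)nc(-c3ccccn3)c2)cc1` differs from compound 2 by pyridin-2-yl in place of thiophen-3-yl on an aromatic carbon. Going by the values given here, the only measured step that bears on this is the one from compound 1 to compound 2, a 3.3-fold lower number from compound 1 to compound 2 (0.52 log units; beyond the scatter), where thiophen-3-yl replaced pyridin-3-yl. Among the compounds with values here, compound 4 runs that change backwards, but with a different pyridine isomer, and no measured pair covers that isomer. A modest rise in the number is therefore expected, smaller than that step. For compound 4 the estimate is 12000 nM, range 4000 nM to 40000 nM. This corresponds to an expected step of a 1.9-fold higher number from compound 2 to compound 4 (0.28 log units; within the scatter).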

Compound 4, half-maximal inhibitory concentration: 21300 nM
Beside the measured number, compound 4's estimate is 1.8-fold (0.25 log units) below it; the range from low to high includes it.
By their numbers in this assay, from the lowest: compounds 3 and 2 (each within the scatter of the next); then compounds 1 and 4 (each within the scatter of the next).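

Placing pyridin-2-yl in place of thiophen-3-yl on the aromatic carbon next to the ring nitrogen gives a 3.4-fold higher number from compound 2 to compound 4 (0.53 log units; beyond the scatter), close in size to the opposite step a 3.3-fold lower number from compound 1 to compound 2 (0.52 log units; beyond the scatter). Moving the pyridine nitrogen makes no difference beyond the scatter, with a 1.0-fold higher number from compound 1 to compound 4 (0.01 log units; within the scatter), so with the 4-chlorophenyl group kept, both pyridines differ from thiophen-3-yl by a similar margin. Nothing available bears on the cause of these steps. Still open, going by these compounds, is how a plain phenyl, a furan-3-yl or a pyridine carrying an amine would fare at this position.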